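A few compounds are considered here, and "the series" means these few. Any claim that something is new, unique, unknown or untested is made for them only; others in the source may bear on it.

Compound 1 `C/C(=N/c1ccnc2cc(Cl)ccc12)NC1CCN(Cc2ccccc2)CC1` is the starting point. In an ADME assay (liver) for metabolic stability, with Liver microsome (Homo sapiens) as the target, read by LC-MS, using microsomes, tested at 1 uM (on this read-out higher numbers stand for a longer-lived compound and lower numbers for a shorter-lived compound), compound 1 gives > 1 h, which is a limit of the assay and not an exact number. Compound 2 `C/C(=N/c1ccnc2cc(Cl)ccc12)NCCCN1CCCCC1`, with a different side chain on the shared core, gives > 1 h, which is also a limit. Going by the values given here, compound 1 therefore has no exact place on the scale, and the only comparison available is the limit of > 1 h in this assay, at which 2 of the 2 values shown sit.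

Compound 3 `C/C(=N/c1ccnc2cc(Cl)ccc12)NC1CCN(C)CC1` exchanges benzyl for methyl, which means hydrogen in place of phenyl on a saturated chain carbon bound to an amine nitrogen in a ring. Among the compounds with values here, no measured pair shows what this change does, so no step beyond the usual scatter is expected in this assay, and no direction is favoured. The expected size of the step that the limit leaves unreadable from compound 1 to compound 3 is small. Compound 3 is estimated at 1.5 h, with an expected range of 0.7 h to 3 h.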

Compound 3, half-life: > 1 h
Compound 3 gave a limit, no number; the forecaster's own chance of this, stated with the estimate: 65%; the middle value lies beyond the limit too.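

Compound 1 and compound 3 each give only a limit and not an exact number, so no step can be read between them: the limit of > 1 h in this assay, at which 3 of the 3 values shown sit.

The compounds shown leave open the exact half-life of each one, and so whether exchanging benzyl for methyl shifts it at all.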